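Aryl swap on the shared core: compound 3 to compound 4

The source may hold more compounds than are shown below. What is called first, only, known or untested is meant among the compounds shown, and "the series" means these compounds.

Of the compounds shown here, three have been measured in an assay on Sf9 cells for inhibition of protein deacetylase HDAC6 (Homo sapiens), read by fluorescence, with a stated time of 40 min, tested at 100 nM; on this read-out lower numbers stand for less inhibition and higher numbers for more inhibition at the one concentration tested (going by the name of the read-out). Compound 1 `COc1ccc(-n2nc(-c3ccccc3)nc2CNc2ccc(C(=O)NO)cc2)cc1` gives 63.4%, and compound 2 `Cc1ccc(-n2nc(-c3ccccc3)nc2CNc2ccc(C(=O)NO)cc2)cc1` gives 60.7%; the step of a number 2.7 percentage points lower from compound 1 to compound 2 (within the scatter) stays within the scatter. Compound 3 `O=C(NO)c1ccc(NCc2nc(-c3ccc(F)cc3)nn2-c2ccccc2)cc1` gives 70.9%, the highest of the three numbers, though compound 1 lies within the scatter of it and only compound 2 lies beyond.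

Compound 4 `O=C(NO)c1ccc(NCc2nc(-c3ccccn3)nn2-c2ccccc2)cc1` differs from compound 3 by pyridin-2-yl in place of 4-fluorophenyl on an aromatic carbon. Among the compounds with values here, no measured step alters this position; the single step measured, a number 2.7 percentage points lower from compound 1 to compound 2 (within the scatter), concerns a substituent on a different phenyl and stayed within the scatter, so in this assay no step beyond the scatter is expected here either. The expected step of a number 5.9 percentage points lower from compound 3 to compound 4 (within the scatter) is small. Compound 4 is estimated at 65%, with a range from 50% to 80%.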

Compound 4, a percentage reported as inhibition, at one concentration (the size of the read-out at that concentration, not a potency): 58.6%
The estimate for compound 4 lay 6.4 percentage points above the measured number, within the range that was stated.
By their numbers in this assay, from the lowest: compounds 4, 2, 1 and 3 (each within the scatter of the next, the first and the last beyond it).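

In this assay this position responds to the aryl group: pyridin-2-yl in place of 4-fluorophenyl gives a number 12.3 percentage points lower from compound 3 to compound 4 (beyond the scatter), unlike the other measured step, which concerned a different phenyl. Within the data shown here, the change removes fluorine and brings in a ring nitrogen and a hydrogen-bond acceptor, and the single step cannot separate these. No measurement at hand bears on the reason for the step. Open, as far as these compounds go, is how a pyridin-3-yl, a pyridin-4-yl or a 4-aminophenyl group would read on this carbon. Also open, from the compounds shown here alone, is whether the step holds with methoxy or methyl on the other phenyl.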